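The source may report more compounds than this note shows. Statements on the series, on what has been measured and on what is new or still open speak of the compounds shown alone.

For the measured compounds named here, compound 1 `N#Cc1ccc(OCC2CCN(CCCF)CC2)cc1` gives 4.3 nM in an assay for binding affinity to Sigma non-opioid intracellular receptor 1 (Rattus norvegicus) (on this read-out higher numbers stand for weaker inhibition and lower numbers for stronger inhibition), the only plain number among the two values shown. Compound 2 `Fc1c(F)c(F)c(CN2CCC(COc3c(F)c(F)c(F)c(F)c3F)CC2)c(F)c1F` stops at a limit of this assay rather than a number, > 1000 nM (the limit of > 1000 nM in this assay, at which 1 of the 2 values shown sits). Compound 3 `N#Cc1ccc(OCC2CCN(Cc3ccc(F)cc3)CC2)cc1` differs from compound 1 in one place: 4-fluorophenyl in place of 2-fluoroethyl on a saturated chain carbon bound to an amine nitrogen in a ring. Going by the values given here, no step between measured compounds is known here, so the size of this change is not fixed by the data; a small move, perhaps within the scatter or a modest gain, is expected. Compound 3 is expected at 3 nM, between 0.8 nM and 15 nM. The estimated step is a 1.4-fold lower number from compound 1 to compound 3 (0.16 log units; within the scatter).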

Compound 3, inhibition constant: 0.76 nM
Estimate against measurement, compound 3: 3.9-fold (0.60 log units) above; measured number outside the range, below it.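

In this assay, the place on a saturated chain carbon bound to an amine nitrogen in a ring accepts an aromatic ring as well as a short fluorinated chain. Putting 4-fluorophenyl in place of 2-fluoroethyl gives a 5.7-fold lower number from compound 1 to compound 3 (0.75 log units; beyond the scatter), so the change improves on a compound that was already in the low range of this read-out. Nothing in the data shown accounts for the size of this step.

Going by these compounds, it remains open whether the gain belongs to the aromatic ring or to its fluorine. On these data alone, how an unsubstituted phenyl, a pyridyl ring or a longer chain at this place would read in this assay also remains open.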